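This account rests on a few compounds, and the source may have more. Where it says the series, first, only, none or still open, it means among the compounds named here.

Compound 1 `CC(O)(CSc1ccc(F)cc1)C(=O)Nc1ccc(S(F)(F)(F)(F)F)cc1` carries a fluoro group on the ring attached to the sulfur. In a functional assay on DU-145 cells (Homo sapiens) for antiproliferative activity, read by propidium iodide staining, with a stated time of 96 h (on this read-out lower numbers stand for stronger inhibition and higher numbers for weaker inhibition), compound 1 gives 25400 nM. Compound 2 `CC(O)(CSc1ccc(C(F)(F)F)cc1)C(=O)Nc1ccc(S(F)(F)(F)(F)F)cc1` is the same molecule with the change (trifluoromethyl in place of fluoro on an aromatic carbon). In this assay compound 2 gives 28800 nM, and the change made the step of a 1.1-fold higher number from compound 1 to compound 2 (0.05 log units; within the scatter).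

Compound 3 `CC(O)(CSc1ccc(F)cc1)C(=O)Nc1cccc(S(F)(F)(F)(F)F)c1` is built from the same atoms as compound 1 but joined differently; the difference between the two cores is not broken down here. In this assay compound 3 gives 38500 nM, a number that lies within the scatter of both compound 1 and compound 2.

Compound 4 `CC(O)(CSc1ccc(C(F)(F)F)cc1)C(=O)Nc1cccc(S(F)(F)(F)(F)F)c1` has not been measured. It differs from compound 3 by the change (trifluoromethyl in place of fluoro on an aromatic carbon), the same change that turned compound 1 into compound 2, made at the same kind of place on the ring.

The step from compound 3 to compound 4 is expected to be a 1.1-fold higher number from compound 3 to compound 4 (0.05 log units; within the scatter) in this assay, because the same change gave a 1.1-fold higher number from compound 1 to compound 2 (0.05 log units; within the scatter). Compound 4 is therefore estimated to give 43000 nM, with a likely range from 25000 nM to 75000 nM.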

Compound 4, half-maximal inhibitory concentration: 27200 nM
The estimate for compound 4 lay 1.6-fold (0.20 log units) above the measured number; low and high end bracket the measured number.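

In this assay the step of a 1.4-fold lower number from compound 3 to compound 4 (0.15 log units; within the scatter) is small, as was the earlier step on the core of compound 1. This does not show that swapping fluoro for trifluoromethyl has no effect at all, or that it has exactly the same effect on both cores: a modest real effect could still hide inside the scatter, and a single pair of cores cannot speak for any other core in the series. What the two steps do show is that this swap gave no measurable sign of depending on the core, as far as these four compounds can tell: the same change on two cores in this assay, a 1.1-fold higher number (0.05 log units; within the scatter) from compound 1 to compound 2 and a 1.4-fold lower number (0.15 log units; within the scatter) from compound 3 to compound 4, 1.6-fold (0.21 log units) apart, within the scatter of two such steps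

Fluoro and trifluoromethyl are the only two groups compared at this place, so it stays open whether a group of a different kind, such as an amine, a carboxylic acid or a longer chain, would give a step beyond the scatter. From the compounds shown here alone, it also stays open whether any such step would carry over from one core to the other as this one did.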